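The source may report more compounds than this note shows. Statements on the series, on what has been measured and on what is new or still open speak of the compounds shown alone.

Measured in a functional assay on A549 cells (Homo sapiens) for antiproliferative activity, read by MTT assay, with a stated time of 48 h; on this read-out lower numbers stand for stronger inhibition and higher numbers for weaker inhibition:
- compound 1 `CC[Si](CC)(CC)C/C1=C/C[C@](C)(CCC=C(C)C)/C=C/[C@@H](OC(=O)C=C(C)C)[C@](C)(O)/C=C/C1=O`: 3100 nM
- compound 2 `CC(C)=CCC[C@]1(C)/C=C/[C@@H](OC(=O)C=C(C)C)[C@](C)(O)/C=C/C(=O)/C(COC(=O)c2ccc([N+](=O)[O-])cc2)=C\C1`: 1310 nM
- compound 3 `CC(C)=CCC[C@]1(C)/C=C/[C@@H](OC(=O)C=C(C)C)[C@](C)(O)/C=C/C(=O)/C(Cn2cc(CO)nn2)=C\C1`: 3470 nM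

Two steps fix the position of compound 3 on these numbers: a 1.1-fold higher number from compound 1 to compound 3 (0.05 log units; within the scatter), and a 2.6-fold higher number from compound 2 to compound 3 (0.42 log units; beyond the scatter). It therefore cannot be separated from compound 1, while compound 2 stands apart from it.

Compound 4 `CSC(=S)OC/C1=C/C[C@](C)(CCC=C(C)C)/C=C/[C@@H](OC(=O)C=C(C)C)[C@](C)(O)/C=C/C1=O` has not been measured. It differs from compound 3 as follows: a group of 5 heavy atoms (2 carbon, 1 oxygen, 2 sulfur; no ring) in place of a group of 7 heavy atoms (3 carbon, 3 nitrogen, 1 oxygen; one five-membered aromatic ring with 3 hetero atoms), on a saturated chain carbon bound to a double-bonded ring carbon.

All three measured steps are changes at this same place. The third is a 2.4-fold lower number from compound 1 to compound 2 (0.37 log units; beyond the scatter). Across these three compounds, exchanging the group has moved the number only modestly, and the exchange from compound 1 to compound 3 has not moved it beyond the scatter. Among the measured compounds shown here, none of the measured compounds carries the entering group, so the data give no direct precedent for it and no firm direction.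

In this assay, a small step is expected, leaning towards the middle of the three measured values. The expected step is a 1.4-fold lower number from compound 3 to compound 4 (0.16 log units; within the scatter). For compound 4 the estimated value is 2400 nM, with an expected range from 1100 nM to 5200 nM.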

Compound 4, half-maximal inhibitory concentration: 380 nM
Beside the measured number, compound 4's estimate is 6.3-fold (0.80 log units) above it; measured number outside the range, below it.
By their numbers in this assay, from the lowest: compound 4; then compound 2; then compounds 1 and 3 (each within the scatter of the next).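

In this assay, among the compounds shown here, the saturated chain carbon bound to a double-bonded ring carbon proves more responsive than the earlier exchanges indicated: the entering sulfur-bearing group without a ring gives a 9.1-fold lower number from compound 3 to compound 4 (0.96 log units; beyond the scatter) and an 8.2-fold lower number from compound 1 to compound 4 (0.91 log units; beyond the scatter), both larger than any step among the earlier compounds. The ((4-nitrophenyl)carbonyl)oxy group of compound 2 no longer marks the low end of the series, since the exchange on the oxygen on a saturated carbon gives a 3.4-fold lower number from compound 2 to compound 4 (0.54 log units; beyond the scatter), and compound 4 therefore stands apart from all three earlier compounds, with an aromatic ring not needed at this place for the lowest number shown here. No measurement at hand accounts for this gain.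

The compounds shown do not tell which part of the entering group matters, and a methyl carbonate, a methyl thioether or a longer alkyl chain on the sulfur would be the direct neighbours for separating those parts. On these data alone, it also stays open whether the order of these four compounds holds outside this single cell read-out, and whether a simple hydroxymethyl or an amine at the same place would fall near compound 4 or near compound 3.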